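The source may hold more compounds than are shown below. What is called first, only, known or untested is meant among the compounds shown, and "the series" means these compounds.

Compound 2 `COc1ccc(/C(Cl)=C/C=C(\C#N)C(=O)c2c[nH]c3ccccc23)cc1` serves as the reference point. In a functional assay for inhibition, with a stated time of 30 min, tested at 1 mM (a lower number here means less inhibition, a higher number more inhibition at the concentration tested (going by the name of the read-out)), compound 2 gives 23.4%. Compound 1 `COc1ccc(/C(Cl)=C/C=C(\C#N)C(=O)c2c[nH]c3ccc(Br)cc23)cc1` carries the change bromo in place of hydrogen on an aromatic carbon and in this assay compound 1 gives 15.6%, a step of a number 7.8 percentage points lower from compound 2 to compound 1 (within the scatter). Compound 3 `COc1ccc(/C(Cl)=C/C=C(\C#N)C(=O)c2c[nH]c3ccccc23)cc1OC` differs from compound 2 by methoxy in place of hydrogen on an aromatic carbon, and in this assay compound 3 gives 15.8%, so the step is a number 7.6 percentage points lower from compound 2 to compound 3 (within the scatter).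

Compound 4 `COc1ccc(/C(Cl)=C/C=C(\C#N)C(=O)c2c[nH]c3ccc(Br)cc23)cc1OC` has not yet been tested. It differs from compound 3 by bromo in place of hydrogen on an aromatic carbon, which is the same change as that from compound 2 to compound 1, made on the core of compound 3 instead. Since the earlier step of a number 7.8 percentage points lower from compound 2 to compound 1 (within the scatter) stayed within the scatter, the step of a number 5.8 percentage points lower from compound 3 to compound 4 (within the scatter) is expected to be of similar size. Compound 4 is therefore estimated to give about 10% in this assay, between 2% and 20%, a figure that rests on compound 3 with 15.8% and the earlier step.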

Compound 4, a percentage reported as inhibition, at one concentration (the size of the read-out at that concentration, not a potency): 11.8%
For compound 4 the middle estimate is 1.8 percentage points below the measured one; the range from low to high includes it.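

In this assay, bromo in place of hydrogen gives a step of a number 4 percentage points lower from compound 3 to compound 4 (within the scatter), and this agrees with the same change on the other core: the same change on two cores in this assay, a number 7.8 percentage points lower (within the scatter) from compound 2 to compound 1 and a number 4 percentage points lower (within the scatter) from compound 3 to compound 4, 3.8 percentage points apart, within the scatter of two such steps. Methoxy in place of hydrogen gives a step of a number 3.8 percentage points lower from compound 1 to compound 4 (within the scatter), and it agrees in the same way: the same change on two cores in this assay, a number 7.6 percentage points lower (within the scatter) from compound 2 to compound 3 and a number 3.8 percentage points lower (within the scatter) from compound 1 to compound 4, 3.8 percentage points apart, within the scatter of two such steps. Neither change therefore gave a different result on the second core, but since all four steps lie within the scatter, this does not show that either change has a real effect of its own, so little is shown to carry over.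

The compounds shown leave open whether an amine, a carboxylic acid or a longer chain in place of the bromo or methoxy group would give a step beyond the scatter.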